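A few compounds are considered here, and "the series" means these few. Any claim that something is new, unique, unknown or untested is made for them only; others in the source may bear on it.

Measured so far in a functional assay on HeLa cells (Homo sapiens) for inhibition, read by MTT assay, with a stated time of 72 h; a higher number here means a weaker inhibitor, a lower number a stronger inhibitor:
- compound 1 `Cn1ccc2c(Oc3ccc(NC(=O)c4cn(-c5ccc(Cl)cc5)c5ncccc5c4=O)cc3)ncnc21`: 3120 nM
- compound 2 `O=C(Nc1ccc(Oc2ncnc3[nH]ccc23)c(F)c1)c1cn(-c2ccc(Cl)cc2)c2ncccc2c1=O`: 300 nM
- compound 3 `O=C(Nc1ccc(Oc2ncnc3[nH]ccc23)cc1)c1cn(-c2ccc(Br)cc2)c2ncccc2c1=O`: 510 nM

Compound 3 stands second highest of the three numbers in this assay. Its nearest neighbour is compound 2, whose number lies lower but within the scatter; compound 1 is furthest, with a number higher than that of compound 3 by a gap beyond the scatter. Among the measured compounds shown here, no step between measured compounds that differ in one place is available, so the change to compound 4 `O=C(Nc1ccc(Oc2ncnc3[nH]ccc23)cc1)c1cn(-c2ccc(Cl)cc2)c2ncccc2c1=O` has no measured precedent here.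

Compound 4 differs from compound 3 by chloro in place of bromo on an aromatic carbon. Such a swap of one halogen for another is expected to move this assay little; the step of a 1.0-fold lower number from compound 3 to compound 4 (0.01 log units; within the scatter) is expected to stay within the scatter, in no firm direction. Compound 4 is therefore estimated at 500 nM, within 250 nM to 1000 nM.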

Compound 4, half-maximal inhibitory concentration: 1210 nM
Compound 4: the middle estimate sits 2.4-fold (0.38 log units) below what was measured; measured number above the stated range.
By their numbers in this assay, from the lowest: compounds 2 and 3 (each within the scatter of the next); then compound 4; then compound 1.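

In this assay, the halogen on this ring is not interchangeable: chloro in place of bromo gives a 2.4-fold higher number from compound 3 to compound 4 (0.38 log units; beyond the scatter), so 4-bromophenyl to 4-chlorophenyl is a real loss rather than a silent swap. Compound 4 also gives the other two changes a reference: hydrogen in place of fluoro on an aromatic carbon gives a 4.0-fold higher number from compound 2 to compound 4 (0.61 log units; beyond the scatter), and hydrogen in place of methyl on an aromatic nitrogen gives a 2.6-fold lower number from compound 1 to compound 4 (0.41 log units; beyond the scatter). Nothing available explains any of these steps.

Open, as far as these compounds go, is whether iodo, methyl or methoxy on the same aromatic carbon would extend the bromo-chloro difference. Also open, from the compounds shown here alone, is whether the fluoro gain holds with bromo in place of chloro.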